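The source may report more compounds than this note shows. Statements on the series, on what has been measured and on what is new or still open speak of the compounds shown alone.

Compound 1 `CO/N=C/c1ccc2ccc(=O)oc2c1` is one of three compounds tested in a functional assay for inhibition of beta-glucuronidase (Bos taurus), tested at 1 mM (a higher number here means a stronger effect of the compound at the concentration tested, a lower number a weaker effect), where compound 1 gives 94.1%. Compound 2 `O=c1ccc2ccc(/C=N/N=C/c3ccc4ccc(=O)oc4c3)cc2o1` gives 100% and compound 3 `O=c1ccc2ccc(/C=N/c3ccccc3)cc2o1` gives 95.4%, so compound 1 stands lowest of the three, though within the scatter of both. Among the measured compounds shown here, the only single-place step, a number 1.3 percentage points higher from compound 1 to compound 3 (within the scatter), swaps what hangs on the double-bonded nitrogen. Compound 4 `CC(O)Cc1ccc2ccc(=O)oc2c1` goes further: a group of 4 heavy atoms (3 carbon, 1 oxygen; no ring) in place of a group of 4 heavy atoms (2 carbon, 1 nitrogen, 1 oxygen; no ring), on an aromatic carbon. For the measured compounds named here, no measured step removes the double-bonded nitrogen itself, so the expectation rests on all three compounds sitting near full inhibition. Compound 4 is therefore estimated at 85%, with a range of 50% to 100%, the expected step being a number 9.1 percentage points lower from compound 1 to compound 4 (within the scatter).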

Compound 4, a percentage reported as inhibition, at one concentration (the size of the read-out at that concentration, not a potency): 92.3%
Beside the measured number, compound 4's estimate is 7.3 percentage points below it, and the stated range covers the measured number.
By their numbers in this assay, from the lowest: compounds 4, 1, 3 and 2 (each within the scatter of the next).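

In this assay, the step of a number 1.8 percentage points lower from compound 1 to compound 4 (within the scatter) shows that on this aromatic carbon, 2-hydroxypropyl can stand in place of the earlier group with no difference beyond the scatter. Among the compounds shown here, compound 4 is the first compound here without a double-bonded nitrogen, so that nitrogen is not needed for this reading. Nothing measured here explains the result.

On these data alone, whether an amine or a carboxylic acid on this carbon would give a similar reading remains open. So does what the hydroxyl of 2-hydroxypropyl contributes, which a plain propyl chain would test.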